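A small aromatic swap starting from an assay limit

The source may report more compounds than this note shows. Statements on the series, on what has been measured and on what is new or still open speak of the compounds shown alone.

Measured in an ADME assay on DU-145 cells (Homo sapiens) for cytotoxicity, read by MTT assay, with a stated time of 72 h; on this read-out higher numbers stand for weaker inhibition and lower numbers for stronger inhibition:
- compound 1 `COc1ccc(C2=C(c3cc(OC)c(OC)c(OC)c3)C(=O)CC2O[SiH2]C(C)(C)C)cc1`: > 100 ug/mL
- compound 2 `COc1ccc(C2=C(c3cc(OC)c(OC)c(OC)c3)C(=O)C(O[SiH2]C(C)(C)C)C2)cc1OC(C)C`: 6.3 ug/mL
- compound 3 `COc1ccc(C2=C(c3cc(OC)c(OC)c(OC)c3)C(=O)CC2O)cc1`: 18.7 ug/mL

Compound 1 stands at the limit of > 100 ug/mL in this assay, at which 1 of the 3 values shown sits. From the compounds shown here alone, that figure is a limit of the assay and not a number, so its true position is unknown.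

Compound 4 `COc1cc(C2=C(c3cc(C)c(OC)c(C)c3)C(O[SiH2]C(C)(C)C)CC2=O)cc(OC)c1OC` differs from compound 1 in one place, with 4-methoxy-3,5-dimethylphenyl in place of 4-methoxyphenyl on a double-bonded ring carbon.

For the measured compounds named here, the only measured step is an at least 5.3-fold lower number from compound 1 to compound 3 (0.72 log units; beyond the scatter). It is beyond the scatter, but it replaces the silicon-bearing group with a hydrogen atom, so it lies elsewhere and gives no direct size for this swap. Compound 2 differs from compound 1 in more than one place, so it offers no clean comparison either.

Compound 4 keeps the silicon-bearing group of compound 1, so it is expected to stay weak in this assay, possibly again reported only as a limit. The expected size of the change is an at least 1.2-fold lower number from compound 1 to compound 4 (0.09 log units; that floor lies within the scatter). For compound 4 the estimate is 80 ug/mL, with an expected range of 20 ug/mL to 200 ug/mL.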

Compound 4, half-maximal inhibitory concentration: > 100 ug/mL
Compound 4: no number, only a limit (the forecaster's own chance of this, stated with the estimate: 50%); middle value at least 1.2-fold (0.09 log units) away from the limit.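

Compound 4 gives > 100 ug/mL in this assay, which is a limit and not a number. Compound 1 also stands at a limit, and the step between compound 1 and compound 4 cannot be read. From the compounds shown here alone, whether 4-methoxy-3,5-dimethylphenyl in place of 4-methoxyphenyl shifts the true value at all stays open.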